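The source may report more compounds than this note shows. Statements on the series, on what has been measured and on what is new or still open speak of the compounds shown alone.

Working notes on the benzyl ether series. Three members have been run in a functional assay on CHO-K1 cells for antagonist activity at prostaglandin E2 receptor EP1 subtype (Homo sapiens), read by FLIPR; on this read-out higher numbers stand for weaker inhibition and lower numbers for stronger inhibition. Compound 1 `O=C(O)c1cncn1Cc1cc(Br)ccc1OCc1ccccc1` returns only a limit, < 2000 nM, a case of the limit of < 2000 nM in this assay, at which 1 of the 3 values shown sits. Compound 2 `Cc1cc(C(=O)O)nn1Cc1cc(Br)ccc1OCc1ccccc1Cl` gives 28.8 nM, the lowest of the two real numbers; compound 3 `Cc1cc(C(=O)O)nn1Cc1cc(Br)ccc1OCc1ccc(C(F)(F)F)cc1` gives 97.7 nM, a gap beyond the usual scatter. Among the measured compounds shown here, no pair of measured compounds differs in one place only, so no measured step is available. Compound 4 `Cc1cc(C(=O)O)nn1Cc1cc(Br)ccc1OCc1cc(Cl)cc(Cl)c1`, not yet measured, differs from compound 2 by 3,5-dichlorophenyl in place of 2-chlorophenyl on a saturated chain carbon bound to an oxygen on an aromatic ring. A modest weakening is expected, a 2.4-fold higher number from compound 2 to compound 4 (0.39 log units; beyond the scatter). This leans on compound 3 with its value of 97.7 nM. Compound 4 is estimated at 70 nM, within 20 nM to 250 nM.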

Compound 4, inhibition constant: 1120 nM
Beside the measured number, compound 4's estimate is 16-fold (1.20 log units) below it; measured number outside the range, above it.
By their numbers in this assay, from the lowest: compound 2; then compound 3; then compound 4.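

In this assay, the aryl group on a saturated chain carbon bound to an oxygen on an aromatic ring proves highly sensitive to change: 3,5-dichlorophenyl in place of 2-chlorophenyl gives a 39-fold higher number from compound 2 to compound 4 (1.59 log units; beyond the scatter). Among the compounds shown here, this is the first single-place step, and it shows that inhibition depends strongly on this group. Compound 1 remains a limit, < 2000 nM, and does not enter this comparison: the limit of < 2000 nM in this assay, at which 1 of the 4 values shown sits.

This one step does not separate the added chlorine from the placement of the chlorines. On these data alone, how a pyridine ring or a longer chain would fare at this place remains open.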